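The source may hold more compounds than are shown below. What is called first, only, known or untested is meant among the compounds shown, and "the series" means these compounds.

Measured compounds:
compound 1, `Cc1cc(C)cc(NC(=O)COc2cc(C)nc3ccc(F)cc23)c1`, 5.79
compound 2, `COc1ccc2nc(C)cc(OC(C)C(=O)Nc3cc(C)cc(C)c3)c2c1`, 5.76
compound 3, `COc1ccc2nc(C)cc(OCC(=O)Nc3cc(C)ccc3OC)c2c1`, 5.65

In a physicochemical assay for lipophilicity, read by HPLC, in phosphate buffer, measured as chromatographic lipophilicity, at pH 7.4 (a higher number here means a more lipophilic compound, a lower number a more polar compound), compound 3 gives 5.65, the lowest of the three numbers, though compound 2 with 5.76 and compound 1 with 5.79 both lie within the scatter of it, so the three cannot be ordered.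

Compound 4, `COc1ccc2nc(C)cc(OCC(=O)Nc3ccncc3)c2c1`, has not yet been measured in this assay. It differs from compound 3 in one place: pyridin-4-yl in place of 2-methoxy-5-methylphenyl on an amide-type nitrogen. For the measured compounds named here, no pair among the measured compounds shows a change of this kind, so no measured step can be carried over.

The expectation is a large downward step, well beyond the scatter, from compound 3 to compound 4 of a number 2.05 log units lower from compound 3 to compound 4 (beyond the scatter) in this assay. Compound 4 is therefore estimated at 3.6, with a range from 2.9 to 4.3.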

Compound 4, distribution coefficient: 2.5
The estimate for compound 4 lay 1.10 log units above the measured number, outside the stated range (below it).
By their numbers in this assay, from the lowest: compound 4; then compounds 3, 2 and 1 (each within the scatter of the next).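

In this assay, pyridin-4-yl in place of 2-methoxy-5-methylphenyl on the amide-type nitrogen gives a number 3.15 log units lower from compound 3 to compound 4 (beyond the scatter) and is the only step shown between compounds that differ in one place. For the compounds shown here, it shows that the number responds strongly to the group on this nitrogen, which the earlier compounds, with no such pair among them, could not show. No measurement shown explains the size of this step.

Where a plain phenyl or a pyridin-3-yl on the same nitrogen would fall remains open. So does how much of the step belongs to the ring nitrogen and how much to the absent methoxy and methyl groups.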